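The source may report more compounds than this note shows. Statements on the series, on what has been measured and on what is new or still open speak of the compounds shown alone.

Of the compounds shown here, three have so far been measured in a physicochemical assay for lipophilicity, measured as octanol-water partition; a higher number here means a more lipophilic compound, a lower number a more polar compound. Compound 1 `CCCc1cn(C/C=C(\C)CCC=C(C)C)nn1` gives 4.5. Compound 3 `CC(C)=CCC/C(C)=C/Cn1cc(-c2ccccc2)nn1` gives 4.91, and compound 2 `CC(C)=CCC/C(C)=C/CC/C(C)=C\Cn1cc(-c2ccccc2)nn1` gives 6.95, the highest of the three. The change from compound 3 to compound 1 is propyl in place of phenyl on an aromatic carbon; it made a step of a number 0.41 log units lower from compound 3 to compound 1 (beyond the scatter). Compound 4 `CCCc1cn(C/C=C(/C)CC/C=C(\C)CCC=C(C)C)nn1` has not been measured; it differs from compound 2 by propyl in place of phenyl on an aromatic carbon, the same change at the same place. How the core of compound 2 differs from that of compound 3 is not broken down here. Because the earlier step was a number 0.41 log units lower from compound 3 to compound 1 (beyond the scatter), a similarly modest lowering is expected this time as well, estimated as a number 0.41 log units lower from compound 2 to compound 4 (beyond the scatter). Compound 4 is accordingly estimated at 6.54, most likely between 6.1 and 6.95.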

Compound 4, partition coefficient: 6.5
The estimate for compound 4 lay 0.04 log units above the measured number, within the range that was stated.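

In this assay, propyl in place of phenyl on the aromatic carbon gives a number 0.45 log units lower from compound 2 to compound 4 (beyond the scatter), in the same direction as and close in size to a number 0.41 log units lower from compound 3 to compound 1 (beyond the scatter), so this change carried over from one core to the other. Going by these compounds alone, these are only two pairs sharing one kind of change, which shows that the step held on these two cores but sets no rule for any other core. Nothing shown here explains why the step has this size.

The compounds shown leave open whether a longer chain such as hexyl, or a group such as an amine or a carboxylic acid, on that aromatic carbon would also give matching steps on both cores.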